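Removing the para-chloro from a trimethoxy chalcone

A few compounds are considered here, and "the series" means these few. Any claim that something is new, unique, unknown or untested is made for them only; others in the source may bear on it.

Measured compounds:
compound 1 `COc1cc(/C=C/C(=O)c2cccc(-n3cc(-c4ccc(Cl)cc4)[nH]c3=O)c2)cc(OC)c1OC` — "not active" (no number reported)
compound 2 `O=C(/C=C/c1cccc(O)c1)c1cccc(-n2cc(-c3ccccc3)[nH]c2=O)c1` — 13300 nM

Compound 1 `COc1cc(/C=C/C(=O)c2cccc(-n3cc(-c4ccc(Cl)cc4)[nH]c3=O)c2)cc(OC)c1OC` was tested in a functional assay on CAKI-1 cells (Homo sapiens) for inhibition (on this read-out lower numbers stand for stronger inhibition of growth and higher numbers for weaker inhibition of growth), and is recorded there as "not active" (no number reported), with no number given, so it cannot be placed on the scale that the other compound occupies. Compound 2 `O=C(/C=C/c1cccc(O)c1)c1cccc(-n2cc(-c3ccccc3)[nH]c2=O)c1`, which carries a hydroxyphenyl in place of the trimethoxyphenyl and a phenyl instead of the 4-chlorophenyl, gives 13300 nM in this assay. Since compound 1 and compound 2 differ in more than one place, their two results show only that one is inactive and the other weakly active.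

Compound 3 `COc1cc(/C=C/C(=O)c2cccc(-n3cc(-c4ccccc4)[nH]c3=O)c2)cc(OC)c1OC` is the next compound, not yet measured. It differs from compound 1 by a single change: hydrogen in place of chloro on an aromatic carbon. Among the compounds with values here, no measured pair shows this step, so its size is unknown; given that compound 1 reports no number and compound 2 is weak, a small effect of either direction, or none beyond the scatter, would fit. Compound 3 is therefore expected to remain weak in this assay, estimated at 25000 nM, with a range from 8000 nM to 80000 nM.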

Compound 3, concentration for 50% growth inhibition: 1750 nM
The estimate for compound 3 lay 14-fold (1.15 log units) above the measured number; measured number below the stated range.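

Compound 1 is recorded as "not active" (no number reported) and compound 3 gives 1750 nM on the same read-out, so no step can be read between them. The compounds shown leave open how large the effect of going from 4-chlorophenyl to phenyl is on growth inhibition. Nothing shown bears on the cause of this result.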